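Swapping the Hydroxamic Tail for a Hydrazide

A few compounds are considered here, and "the series" means these few. Any claim that something is new, unique, unknown or untested is made for them only; others in the source may bear on it.

Three compounds share a core built around a five-membered aromatic ring with one nitrogen. Compound 1 `Cn1cc(C(=O)c2ccccc2)cc1/C=C/C(=O)NCCO` carries a 2-hydroxyethyl amide on an ethenyl linker; compound 2 `Cn1cc(C(=O)c2ccccc2)cc1CCC(=O)NO` carries a hydroxamic acid on a saturated linker; compound 3 `Cn1cc(C(=O)c2ccc(Cl)cc2)cc1/C=C/C(=O)NO` carries a hydroxamic acid on an ethenyl linker and a chlorine on its phenyl ring. In an assay on isolated protein for inhibition of histone deacetylase HD2 (Zea mays), tested at 30 uM (on this read-out lower numbers stand for less inhibition and higher numbers for more inhibition at the one concentration tested (going by the name of the read-out)), compound 1 gives 0.9%, compound 2 gives 45% and compound 3 gives 87%. Compound 2 thus stands second of the three: below compound 3 by a gap beyond the scatter, and above compound 1 by a gap that is also beyond the scatter.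

Compound 4 `Cn1cc(C(=O)c2ccccc2)cc1/C=C/C(=O)NN` has not yet been measured. Relative to compound 2 the change is 2-(aminocarbamoyl)ethenyl in place of 2-(hydroxycarbamoyl)ethyl on an aromatic carbon, so the hydroxyl on the amide nitrogen becomes an amino group and the saturated linker becomes an unsaturated one. Within the data shown here, no single-change step between measured compounds is known here. Because compound 1, whose tail also lacks the hydroxycarbamoyl group, gives 0.9%, a sizeable drop in this assay is expected for a number 27 percentage points lower from compound 2 to compound 4 (beyond the scatter). Compound 4 is estimated at 18%, within a range from 2% to 55%.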

Compound 4, a percentage reported as inhibition, at one concentration (the size of the read-out at that concentration, not a potency): 0.2%
For compound 4 the middle estimate is 17.8 percentage points above the measured one; measured number outside the range, below it.
By their numbers in this assay, from the lowest: compounds 4 and 1 (each within the scatter of the next); then compound 2; then compound 3.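

In this assay, the change at this ring carbon gives a number 44.8 percentage points lower from compound 2 to compound 4 (beyond the scatter), a large step, so 2-(aminocarbamoyl)ethenyl does not keep the inhibition seen with 2-(hydroxycarbamoyl)ethyl. The second step shows what happens on the amide-type nitrogen: amino in place of 2-hydroxyethyl gives a number 0.7 percentage points lower from compound 1 to compound 4 (within the scatter), which lies within the scatter, so this assay does not tell these two tails apart, and a hydrazide tail reads no differently here from a 2-hydroxyethyl amide tail. Nothing available here explains the loss of inhibition seen with this change.

As far as these compounds go, the step from compound 2 to compound 4 alters the linker and the end group together, so the share of each remains open, and compound 3 cannot settle it, as it also carries a chlorine on its phenyl ring. Among these compounds, only the pair 2-(hydroxycarbamoyl)ethenyl and 2-(aminocarbamoyl)ethyl on the unchlorinated core would separate the two changes, and how a carboxylic acid or a primary amide at the end of the chain would read also stays unknown.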